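The source may hold more compounds than are shown below. What is called first, only, known or untested is meant among the compounds shown, and "the series" means these compounds.

In an ADME assay on S9 fraction from liver (Rattus norvegicus) for metabolic stability, read by LC-MS, using NADPH, with a stated time of 30 min (a lower number here means that less of the compound is left, a higher number that more of the compound is left), compound 1 `CCCCCCCCc1ccc(OCC(=O)Cn2nnc(-c3ccc(C(=O)OC)cc3)n2)cc1` gives 64%. Among the compounds with values here, compound 3 `CCCCCCCCc1ccc(OCC(=O)Cn2nnc(-c3cccs3)n2)cc1` gives 8%, the lower of the only two true numbers so far. Compound 2 `CCCCCCCCc1ccc(OCC(=O)Cn2nnc(-c3ccncc3)n2)cc1` gives < 5%, which is a limit of the assay and not a number.

The measured steps all swap one group on the shared core. Pyridin-4-yl in place of 4-(methoxycarbonyl)phenyl gives a number at least 59 percentage points lower from compound 1 to compound 2 (beyond the scatter), and thiophen-2-yl in its place gives a number 56 percentage points lower from compound 1 to compound 3 (beyond the scatter). The step between the two lower compounds is a number at least 3 percentage points higher from compound 2 to compound 3 (that floor lies within the scatter). So a change at this place can move the number a long way.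

Compound 4 `CCCCCCCCc1ccc(OCC(=O)Cn2nnc(CCC(=O)O)n2)cc1` carries a new kind of group, with 2-carboxyethyl in place of thiophen-2-yl on an aromatic carbon, and the count of that change is 2-carboxyethyl in place of thiophen-2-yl on an aromatic carbon. Within the data shown here, none of the measured steps makes this exact swap, so they suggest a size more firmly than a direction. Compound 3 already lies near the bottom of the scale at 8%, which leaves most of the room upward.

The expected change in this assay is therefore a sizeable rise, estimated as a number 32 percentage points higher from compound 3 to compound 4 (beyond the scatter). For compound 4 the estimate is 40%, with an expected range from 10% to 75%.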

Compound 4, percent of the compound remaining: < 5%
Compound 4 ended at the assay's limit; the forecaster's own chance of this, stated with the estimate: 10%; at least 35 percentage points between middle value and limit.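

In this assay compound 4 gives < 5%, which is a limit of the assay and not a number. Until now this place on the shared core carried only aromatic rings, and the open-chain 2-carboxyethyl group brings no rise: the change is a number at least 3 percentage points lower from compound 3 to compound 4 (that floor lies within the scatter), and against the best compound it is a number at least 59 percentage points lower from compound 1 to compound 4 (beyond the scatter). The step from compound 2 to compound 4 cannot be read because both compounds stand at the same limit: the limit of < 5% in this assay, at which 2 of the 4 values shown sit.

On these data alone, whether the high reading of compound 1 comes from its phenyl ring or from the methoxycarbonyl group on that ring stays open, and a plain phenyl group would help to separate the two. Also open, as far as these compounds go, is whether the methyl ester of the 2-carboxyethyl chain, or a longer chain ending in a carboxylic acid, would leave more compound.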